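The source may report more compounds than this note shows. Statements on the series, on what has been measured and on what is new or still open speak of the compounds shown alone.

Working notes on the series. The shared core is carried by compound 1 `Cc1[nH]nc(N)c1-c1ccc(Br)cc1`, compound 2 `Cc1[nH]nc(N)c1-c1cc(C(F)(F)F)cc(C(F)(F)F)c1` and compound 3 `CCCC(=O)n1nc(C)c(-c2ccc(Cl)c(Cl)c2)c1N`, which differ in the aryl group and in the substituent on the ring nitrogen. In an assay on Sf9 cells for inhibition of mitogen-activated protein kinase kinase kinase 14 (Homo sapiens), read by ADP-Glo, with a stated time of 60 min (on this read-out higher numbers stand for weaker inhibition and lower numbers for stronger inhibition), compound 1 gives > 100000 nM, which is a limit of the assay and not a number. In this assay compound 2 gives > 100000 nM, again a limit rather than a number. In this assay compound 3 gives > 100000 nM, also a limit. Going by the values given here, compound 3 therefore stands where every value shown stands, namely at the limit of > 100000 nM in this assay, at which 3 of the 3 values shown sit, and no step between measured compounds can be counted from these data.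

Compound 4 `Cc1nn(C(=O)c2ccccc2)c(N)c1-c1ccc(Cl)c(Cl)c1` has not yet been measured. It differs from compound 3 by phenyl in place of propyl on a carbonyl carbon. With every known value sitting at the limit, the step from compound 3 to compound 4 in this assay is expected to be small, as a step that the limit leaves unreadable from compound 3 to compound 4 states. Compound 4 is expected to give about 150000 nM in this assay, within a range from 30000 nM to 600000 nM. The most likely outcome for compound 4 is that this assay again reports only a limit.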

Compound 4, half-maximal inhibitory concentration: 23000 nM
Estimate against measurement, compound 4: 6.5-fold (0.81 log units) above; the measured number lies below the stated range.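

Going by these compounds alone, compound 4 gives the first reading in this assay that is a number and not a limit, which shows that the group on this carbonyl carbon can move the read-out. Phenyl in place of propyl gives an at least 4.3-fold lower number from compound 3 to compound 4 (0.63 log units; beyond the scatter). That step is a minimum and not a measured size, because the value of compound 3 is itself a limit: the limit of > 100000 nM in this assay, at which 3 of the 4 values shown sit.

The compounds shown leave open whether the step follows from the aromatic ring or simply from the larger group, a question that a cyclohexyl ring, a benzyl group or a longer chain on the same carbonyl carbon would address. Also open, as far as these compounds go, is how a methoxy group or an amine on the phenyl ring, or a different aryl group on the shared core, would read alongside compound 4.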